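This account rests on a few compounds, and the source may have more. Where it says the series, first, only, none or still open, it means among the compounds named here.

Compound 1 `Cc1nc(C)c(-c2nnc(-c3ccc(OC(C)C)c(Cl)c3)s2)s1`: 7.76
Compound 2 `Cc1[nH]ncc1-c1nnc(-c2ccc(OC(C)C)c(Cl)c2)s1`: 5.45
Compound 3 `CC(C)Oc1ccc(-c2nnc(-c3ccno3)s2)cc1Cl`: 6.93

In a physicochemical assay for lipophilicity, at pH 7.4 (a lower number here means a more polar compound, a higher number a more lipophilic compound), compound 2 stands lowest of the three at 5.45. Compound 4 `Cc1c(-c2nnc(-c3ccc(OC(C)C)c(Cl)c3)s2)cnn1CCC(=O)O` differs from compound 2 in one place: 2-carboxyethyl in place of hydrogen on an aromatic nitrogen. Among the measured compounds shown here, no measured step changes anything on that aromatic nitrogen, so the evidence is only indirect. Exchanges of the whole group on the shared core gave large steps, a number 2.31 log units lower from compound 1 to compound 2 (beyond the scatter) and a number 1.48 log units higher from compound 2 to compound 3 (beyond the scatter), and a modest one, a number 0.83 log units lower from compound 1 to compound 3 (beyond the scatter). A large step is therefore expected here, downward, a number 1.25 log units lower from compound 2 to compound 4 (beyond the scatter). For the measured compounds named here, that direction is a judgement on the entering 2-carboxyethyl group, which no measured compound carries. The estimate for compound 4 is 4.2, with an expected range of 2.8 to 5.6.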

Compound 4, distribution coefficient: 3.16
Compound 4: the middle estimate sits 1.04 log units above what was measured; the measured number falls inside the stated range.
By their numbers in this assay, from the lowest: compound 4; then compound 2; then compound 3; then compound 1.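

Among the compounds shown here, compound 4 gives the first reading on the aromatic nitrogen: in this assay, 2-carboxyethyl in place of hydrogen gives a number 2.29 log units lower from compound 2 to compound 4 (beyond the scatter). This position can therefore carry a large downward step without any exchange of the whole group on the shared core. No measurement on hand accounts for the size of this step.

From the compounds shown here alone, whether the step follows the carboxylic acid or the chain carrying it stays open. A plain propyl chain, a methyl ester or an amine on that aromatic nitrogen would separate the two.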